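A hydroxy group added to compound 2

This account rests on a few compounds, and the source may have more. Where it says the series, first, only, none or still open, it means among the compounds named here.

Measured in a functional assay on A2780 cells (Homo sapiens) for inhibition, read by sulforhodamine B assay; on this read-out higher numbers stand for weaker inhibition of growth and lower numbers for stronger inhibition of growth:
- Compound 1 `COc1ccc(-c2ccc(-c3ccc(-c4nc5ccccc5[nH]4)cc3)cc2)cc1OC`: 21600 nM
- Compound 2 `COc1cc(-c2ccc(-c3ccc(-c4nc5ccccc5[nH]4)cc3)cc2)cc(OC)c1OC`: 9210 nM
- Compound 3 `Oc1cccc2[nH]c(-c3ccc(-c4ccc(-c5ccccc5)cc4)cc3)nc12`: 41000 nM

Of these three, compound 2 has the lowest number and so shows the strongest inhibition of growth. The next compound to be tested, compound 4 `COc1cc(-c2ccc(-c3ccc(-c4nc5c(O)cccc5[nH]4)cc3)cc2)cc(OC)c1OC`, differs from it by hydroxy in place of hydrogen on an aromatic carbon. In words, this is hydroxy in place of hydrogen on an aromatic carbon, turning 1H-benzimidazol-2-yl into 4-hydroxy-1H-benzimidazol-2-yl.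

For the measured compounds named here, the only measured step, a 2.3-fold lower number from compound 1 to compound 2 (0.37 log units; beyond the scatter), is modest and concerns a methoxy at the other end of the molecule, so it bears only indirectly. Going by the values given here, no measured step isolates the hydroxy. Compound 3 carries the same hydroxy but no methoxy groups, and it gives 41000 nM, which hints weakly at a higher number. No step beyond the scatter is therefore the best expectation, with a slight lean upward: the expected change is a 1.2-fold higher number from compound 2 to compound 4 (0.08 log units; within the scatter). For compound 4 the estimated value is 11000 nM, with an expected range from 3000 nM to 35000 nM.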

Compound 4, concentration for 50% growth inhibition: 170 nM
Estimate against measurement, compound 4: 65-fold (1.81 log units) above, and the stated range ends above it.
By their numbers in this assay, from the lowest: compound 4; then compound 2; then compounds 1 and 3 (each within the scatter of the next).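

In this assay, the change from 1H-benzimidazol-2-yl to 4-hydroxy-1H-benzimidazol-2-yl gives a 54-fold lower number from compound 2 to compound 4 (1.73 log units; beyond the scatter), so one added hydroxy on this aromatic carbon outweighs the earlier methoxy change, which gave a 2.3-fold lower number from compound 1 to compound 2 (0.37 log units; beyond the scatter). Compound 3 also carries this hydroxy, but it has no partner among these compounds that differs from it in one place, so only this new pair isolates the hydroxy and shows that this position can strongly affect growth inhibition. Nothing given here explains why the step is so large.

From the compounds shown here alone, it remains open whether an amine or a carboxylic acid on the same aromatic carbon would match the hydroxy. Going by these compounds, the hydroxy step can also be read only with the methoxy groups of compound 2 in place, so its size alongside other groups remains unknown.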